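Thiophene swap on the propyl-linked compound 2

The compounds below may be only part of what the source reports. "The series", "measured", "known", "first", "only" and "open" are said of these compounds alone.

- compound 1 `COc1cc(/C=C/C(=O)/C=C/c2cccs2)ccc1OCc1cn(CCCCCOc2cc(=O)oc3ccccc23)nn1` gives 30%
- compound 2 `COc1cccc(/C=C/C(=O)/C=C/c2ccc(OCc3cn(CCCOc4cc(=O)oc5ccccc45)nn3)c(OC)c2)c1` gives 52%
- compound 3 `COc1cc(/C=C/C(=O)/C=C/c2cc(OC)c(OC)c(OC)c2)ccc1OCc1cn(CCCCCOc2cc(=O)oc3ccccc23)nn1` gives 51%

In a functional assay on COLO 205 cells (Homo sapiens) for inhibition, read by sulforhodamine B assay, with a stated time of 48 h, tested at 50 uM (a higher number here means more inhibition of growth at the concentration tested, a lower number less inhibition of growth), compound 2 and compound 3 lie within the scatter of each other, and both lie beyond the scatter above compound 1. Compound 4 `COc1cc(/C=C/C(=O)/C=C/c2cccs2)ccc1OCc1cn(CCCOc2cc(=O)oc3ccccc23)nn1` differs from compound 2 by one change: thiophen-2-yl in place of 3-methoxyphenyl on a double-bonded chain carbon bound to a double-bonded chain carbon. Going by the values given here, one measured step bears on this place: a number 21 percentage points higher from compound 1 to compound 3 (beyond the scatter). There thiophen-2-yl is the group that leaves, so the reverse change would be expected to lower the number. That step has a different partner group and a different chain from compound 2, so it is only a rough guide. In this assay the expected change is a modest drop: a number 16 percentage points lower from compound 2 to compound 4 (beyond the scatter). For compound 4 the estimate is 36%, with an expected range from 20% to 52%.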

Compound 4, percent growth inhibition at one concentration: 55%
The estimate for compound 4 lay 19 percentage points below the measured number; measured number outside the range, above it.
By their numbers in this assay, from the lowest: compound 1; then compounds 3, 2 and 4 (each within the scatter of the next).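

In this assay the thiophen-2-yl swap gives a number 3 percentage points higher from compound 2 to compound 4 (within the scatter), so at this place the group can stand in for 3-methoxyphenyl with no separable difference. The thiophen-2-yl group therefore does not bring a low number wherever it stands, although the other step at this place reads a number 21 percentage points higher from compound 1 to compound 3 (beyond the scatter), with a different partner group and chain. Nothing available explains why the two steps differ.

On these data alone, it remains open how a furan-2-yl group, or a phenyl ring carrying an amine or a carboxylic acid, would read at this place.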